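Trimming the Indole Amide from Compound 3

The compounds below may be only part of what the source reports. "The series", "measured", "known", "first", "only" and "open" are said of these compounds alone.

Measured so far:
compound 1, `CC[C@@H]1C(=O)N(C)c2cnc(Nc3ccc(S(=O)(=O)NC4CCCC4)cc3)nc2N1C1CCCC1`, gives 23.9 nM
compound 2, `CCC1C(=O)N(C)c2cnc(-n3ccc4cc(C(=O)NCC(C)C)ccc43)nc2N1c1ccn(C)n1`, gives 159 nM
compound 3, `CC[C@@H]1C(=O)N(C)c2cnc(-n3ccc4cc(C(=O)NC(C)C)ccc43)nc2N1C1CCCC1`, gives 17.4 nM

In an assay for inhibition of serine/threonine-protein kinase PLK2 (Homo sapiens), read by FRET and Z'-LYTE, with a stated time of 1 h (on this read-out higher numbers stand for weaker inhibition and lower numbers for stronger inhibition), compound 3 gives 17.4 nM, the lowest of the three numbers. Compound 1 at 23.9 nM sits within the usual scatter of compound 3, so no order between the two can be claimed, while compound 2 at 159 nM lies well beyond it.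

Compound 4, `CC[C@@H]1C(=O)N(C)c2cnc(-n3ccc4ccccc43)nc2N1C1CCCC1`, differs from compound 3 by hydrogen in place of isopropylcarbamoyl on an aromatic carbon. Going by the values given here, no measured pair isolates this change, so the expectation rests on the bare loss of the isopropylcarbamoyl group. A moderate weakening beyond the scatter is expected, an estimated step of a 2.9-fold higher number from compound 3 to compound 4 (0.46 log units; beyond the scatter). Compound 4 is therefore estimated at 50 nM, with a likely range from 15 nM to 200 nM.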

Compound 4, half-maximal inhibitory concentration: 355 nM
Compound 4: the middle estimate sits 7.1-fold (0.85 log units) below what was measured; measured number above the stated range.
By their numbers in this assay, from the lowest: compounds 3 and 1 (each within the scatter of the next); then compound 2; then compound 4.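

In this assay, hydrogen in place of isopropylcarbamoyl gives a 20-fold higher number from compound 3 to compound 4 (1.31 log units; beyond the scatter), so this group on the six-membered aromatic ring contributes substantially to the inhibition seen with compound 3. Going by these compounds alone, this is the first change in a single place among the compounds, and it shows that this position is far from indifferent. No evidence at hand bears on the reason for the size of this loss.

The compounds shown leave open which part of the group matters, the isopropyl or the amide itself. As far as these compounds go, whether a primary carboxamide, a carboxylic acid or a longer chain on the amide would hold the inhibition of compound 3 also remains open.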